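The compounds below may be only part of what the source reports. "The series", "measured", "known", "first", "only" and "open" are said of these compounds alone.

Measured in a functional assay on HeLa cells (Homo sapiens) for antiproliferative activity, read by sulforhodamine B assay, with a stated time of 48 h; a higher number here means a weaker inhibitor, a lower number a stronger inhibitor:
Compound 1 `COc1ccc(C[C@@H](O)/C=C/C=C/C(=O)N2CCN(C)CC2)cc1OC`: 16500 nM
Compound 2 `CCN1CCN(C(=O)/C=C/C=C/[C@H](O)Cc2ccc(OC)c(OC)c2)CC1`: 11700 nM

Among the measured compounds shown here, compound 2 stands level with its only measured neighbour: a 1.4-fold lower number from compound 1 to compound 2 (0.15 log units; within the scatter). Compound 3 `COc1ccc(C[C@@H](O)/C=C/C=C/C(=O)N2CCN(c3ccccn3)CC2)cc1OC` changes the same amine nitrogen in a ring, with pyridin-2-yl in place of ethyl on an amine nitrogen in a ring. For the measured compounds named here, the one measured step bearing on this, a 1.4-fold lower number from compound 1 to compound 2 (0.15 log units; within the scatter), only lengthened a saturated chain, and no measured compound carries a ring at this place. It therefore gives no ground for expecting a step beyond the scatter in this assay, though the guide is weak. For compound 3 the estimated value is 9000 nM, with an expected range from 3500 nM to 20000 nM. This estimate means an expected 1.3-fold lower number from compound 2 to compound 3 (0.11 log units; within the scatter).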

Compound 3, half-maximal inhibitory concentration: 23600 nM
Compound 3: middle estimate off by 2.6-fold (0.42 log units), on the low side; measured number above the stated range.
By their numbers in this assay, from the lowest: compounds 2, 1 and 3 (each within the scatter of the next).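

In this assay, the amine nitrogen in the ring carries a six-membered aromatic ring, pyridin-2-yl, and the step from ethyl stays within the scatter (a 2.0-fold higher number from compound 2 to compound 3 (0.30 log units; within the scatter)). The step from methyl does too (a 1.4-fold higher number from compound 1 to compound 3 (0.16 log units; within the scatter)), so this larger group, with its added hydrogen-bond acceptor, gives no measurable separation from either small chain. No supporting measurement speaks to why these numbers stay so close.

Going by these compounds, whether phenyl, benzyl or a chain ending in a carboxylic acid at this nitrogen would give a step beyond the scatter stays open. So does whether a different attachment point on the pyridine ring, as in pyridin-4-yl, would do so.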